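Shared Core, New Aryl: Cytotoxicity Outlook for Compound 4

The source may report more compounds than this note shows. Statements on the series, on what has been measured and on what is new or still open speak of the compounds shown alone.

Compound 3 `COc1cc(N2C(N)=C(C#N)C(c3ccc(C)cc3)C3=C2CC(C)(C)CC3=O)cc(OC)c1OC` gives 52900 nM in a functional assay on Ehrlich cells (Mus musculus) for cytotoxicity (on this read-out lower numbers stand for stronger inhibition and higher numbers for weaker inhibition), and compound 2 `COc1cc(N2C(N)=C(C#N)C(c3ccc(O)cc3)C3=C2CC(C)(C)CC3=O)cc(OC)c1OC` gives 75800 nM, a number within the scatter of compound 3. Compound 1 `COc1cc(N2C(N)=C(C#N)C(c3cccc([N+](=O)[O-])c3)C3=C2CC(C)(C)CC3=O)cc(OC)c1OC` is recorded as "not active" (no number reported) in this assay, with no number. Among the compounds with values here, the only measured step, a 1.4-fold lower number from compound 2 to compound 3 (0.16 log units; within the scatter), exchanges a single small group for another and stays within the scatter. Compound 4 `COc1cc(N2C(N)=C(C#N)C(c3c(OC)ccc4ccccc34)C3=C2CC(C)(C)CC3=O)cc(OC)c1OC` differs from compound 3 by 2-methoxynaphthalen-1-yl in place of 4-methylphenyl on a saturated ring carbon. Within the data shown here, no measured step exchanges the whole aryl group, so the data give no ground for a shift beyond the scatter in either direction. Compound 4 is therefore expected near 50000 nM, with a range from 15000 nM to 200000 nM. That estimate corresponds to a 1.1-fold lower number from compound 3 to compound 4 (0.02 log units; within the scatter), expected to remain within the scatter.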

Compound 4, half-maximal inhibitory concentration: "not active" (no number reported)
Nothing numeric was reported for compound 4; no gap can be computed for the estimate.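

In this assay compound 4 is recorded as "not active" (no number reported), so no step from compound 3 can be read, and no evidence shown bears on this result. The compounds shown leave open how 2-methoxynaphthalen-1-yl compares numerically with 4-methylphenyl on the shared core.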